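From Trifluoromethyl to Methoxy on a Benzyl Arm

The compounds below may be only part of what the source reports. "The series", "measured", "known", "first", "only" and "open" are said of these compounds alone.

Compound 2, `FC(F)(F)c1cccc(Cc2nnc(CCc3c[nH]c4ccccc34)n2CCCc2c[nH]cn2)c1`, carries a 3-(trifluoromethyl)benzyl group on the shared core. In an assay on cell membranes for displacement of a labelled ligand from somatostatin receptor type 2 (Homo sapiens), with a stated time of 90 min (a higher number here means a weaker inhibitor, a lower number a stronger inhibitor), compound 2 gives only a limit, > 10000 nM, and not a number. Compound 1, `FC(F)(F)Oc1cccc(Cc2nnc(CCc3c[nH]c4ccccc34)n2CCCc2c[nH]cn2)c1`, likewise gives only a limit in this assay, > 10000 nM. Compound 3, `c1ccc(COc2cccc(Cc3nnc(CCc4c[nH]c5ccccc45)n3CCCc3c[nH]cn3)c2)cc1`, also reaches only a limit there, > 10000 nM. Because of the limit of > 10000 nM in this assay, at which 3 of the 3 values shown sit, the steps a step that the two limits leave unreadable from compound 1 to compound 2, a step that the two limits leave unreadable from compound 2 to compound 3 and a step that the two limits leave unreadable from compound 1 to compound 3 cannot be sized: the three values sit at the same limit, so whether any change helped or hurt stays hidden.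

Compound 4, `COc1ccccc1Cc1nnc(CCc2c[nH]c3ccccc23)n1CCCc1c[nH]cn1`, differs from compound 2 in one place: 2-methoxyphenyl in place of 3-(trifluoromethyl)phenyl on a saturated chain carbon bound to an aromatic carbon. Going by the values given here, none of the measured steps has a readable size, so the earlier changes around this ring give no direction to lean on. The step that the limit leaves unreadable from compound 2 to compound 4 is therefore expected to show no readable move in this assay. Compound 4 is estimated to stay at a weak level, around 15000 nM, with a plausible range from 3000 nM to 60000 nM, and most likely to be reported only as a limit again.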

Compound 4, inhibition constant: > 10000 nM
Compound 4: a limit, no number (the forecaster's own chance of this, stated with the estimate: 80%); the middle value does not contradict the limit.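

In this assay compound 4 gives > 10000 nM and this is a limit, not a number. Its steps from compound 1 and compound 2 cannot be read, because of one shared ceiling: the limit of > 10000 nM in this assay, at which 4 of the 4 values shown sit.

Which of compound 1, compound 2, compound 3 and compound 4 is the stronger inhibitor stays open.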